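Replacing 2,3-dichlorophenyl with 2,3,4-trimethoxyphenyl in compound 2

The source may report more compounds than this note shows. Statements on the series, on what has been measured and on what is new or still open speak of the compounds shown alone.

Of the compounds shown here, three sharing one core have been measured so far. In a functional assay on PC-3 cells (Homo sapiens) for cytotoxicity, read by MTT assay, with a stated time of 72 h (a lower number here means a stronger inhibitor, a higher number a weaker inhibitor), compound 1 `COc1ccc(OC)c(/C=C/C(=O)Nc2cc3c(Nc4ccc(F)c(Cl)c4)ncnc3cc2OC)c1` gives 28600 nM, compound 2 `O=C(/C=C/c1cccc(Cl)c1Cl)Nc1cc2c(Nc3ccc(F)c(Cl)c3)ncnc2cc1O[C@H]1CCOC1` gives 27500 nM and compound 3 `COc1cc2ncnc(Nc3ccc(F)c(Cl)c3)c2cc1NC(=O)/C=C/c1ccccc1[N+](=O)[O-]` gives 14300 nM. Compound 2 lies within the scatter of both other compounds, so these values set no order among the three.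

The next compound to be read is compound 4 `COc1ccc(/C=C/C(=O)Nc2cc3c(Nc4ccc(F)c(Cl)c4)ncnc3cc2O[C@H]2CCOC2)c(OC)c1OC`, which carries 2,3,4-trimethoxyphenyl in place of 2,3-dichlorophenyl on a double-bonded chain carbon bound to a double-bonded chain carbon.

Going by the values given here, one measured step bears on this change, as it also exchanges the aryl group on the chain: a 2.0-fold lower number from compound 1 to compound 3 (0.30 log units; within the scatter), with 2-nitrophenyl in place of 2,5-dimethoxyphenyl. Among the compounds with values here, that step involves other groups than the present pair, and the data hold no measured step for 2,3,4-trimethoxyphenyl, so it is only a rough guide. Since a 2.0-fold lower number from compound 1 to compound 3 (0.30 log units; within the scatter) stays within the scatter, no shift beyond the scatter in either direction is expected in this assay.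

Within the data shown here, the expected change is a 1.3-fold lower number from compound 2 to compound 4 (0.10 log units; within the scatter), which would be no real step. The estimate for compound 4 is 22000 nM, with an expected range of 9000 nM to 50000 nM.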

Compound 4, half-maximal inhibitory concentration: 7670 nM
Beside the measured number, compound 4's estimate is 2.9-fold (0.46 log units) above it; the whole stated range lies above it.
By their numbers in this assay, from the lowest: compounds 4, 3, 2 and 1 (each within the scatter of the next, the first and the last beyond it).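

In this assay, a 3.6-fold lower number from compound 2 to compound 4 (0.55 log units; beyond the scatter) is a modest step, but unlike a 2.0-fold lower number from compound 1 to compound 3 (0.30 log units; within the scatter) it lies beyond the scatter, so the group on a double-bonded chain carbon bound to a double-bonded chain carbon can shift the number measurably in this series. The exchange removes 2,3-dichlorophenyl, with its 8 heavy atoms and 0 hydrogen-bond acceptors, and brings in 2,3,4-trimethoxyphenyl, with 12 heavy atoms and 3 hydrogen-bond acceptors, so this single step cannot separate the loss of the two chlorines from the gain of the three methoxy groups. No supporting data are available to explain the step.

A plain phenyl group or a phenyl carrying a single methoxy group at this place would help show whether the lower number follows the removal of chlorine, the addition of methoxy groups or both. As far as these compounds go, it also remains open whether the same exchange would give a similar step on compounds carrying the methoxy group of compound 1 on the shared core.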